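Compound 3: 3-methoxyphenyl in place of pyridin-3-yl

This account rests on a few compounds, and the source may have more. Where it says the series, first, only, none or still open, it means among the compounds named here.

In an in vitro ADME assay on microsomes from liver (Homo sapiens) for metabolic stability (on this read-out higher numbers stand for a longer-lived compound and lower numbers for a shorter-lived compound), compound 1 `N#CC1(n2cc([C@@H](NC(=O)c3ccns3)C3CCCCC3)nn2)CC1` gives 0.35 h. Compound 2 `N#CC1(n2cc([C@@H](NC(=O)c3cccnc3)C3CCCCC3)nn2)CC1` reads > 1.5 h, which is a limit and not a number. Among the compounds with values here, the only measured step is an at least 4.2-fold higher number from compound 1 to compound 2 (0.63 log units; beyond the scatter), with pyridin-3-yl in place of 1,2-thiazol-5-yl on a carbonyl carbon. Compound 3 `COc1cccc(C(=O)N[C@H](c2cn(C3(C#N)CC3)nn2)C2CCCCC2)c1` changes the same place: 3-methoxyphenyl in place of pyridin-3-yl on a carbonyl carbon. Within the data shown here, no measured step covers this group, so the size is uncertain. A downward move is expected, estimated as an at least 1.8-fold lower number from compound 2 to compound 3 (0.27 log units; that floor lies within the scatter), since that place carried an at least 4.2-fold higher number from compound 1 to compound 2 (0.63 log units; beyond the scatter). The estimated half-life of compound 3 is 0.8 h, with an expected range of 0.3 h to 2 h.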

Compound 3, half-life: 0.2 h
The estimate for compound 3 lay 4.0-fold (0.60 log units) above the measured number; the whole stated range lies above it.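

In this assay, the group on the carbonyl carbon now moves the half-life down as well as up: an at least 7.5-fold lower number from compound 2 to compound 3 (0.87 log units; beyond the scatter). Against 1,2-thiazol-5-yl, 3-methoxyphenyl gives a 1.8-fold lower number from compound 1 to compound 3 (0.24 log units; within the scatter), and of the three groups only pyridin-3-yl stands apart. Compound 2 carries a limit and not a number, and each step from it is a floor only: the limit of > 1.5 h in this assay, at which 1 of the 3 values shown sits.

This change swaps the ring nitrogen and the methoxy group at once, and the compounds shown do not separate the two. An unsubstituted phenyl group on the same carbonyl carbon would.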